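The source may hold more compounds than are shown below. What is called first, only, known or untested is meant among the compounds shown, and "the series" means these compounds.

In a functional assay on HCT-116 cells (Homo sapiens) for inhibition, read by sulforhodamine B assay, with a stated time of 48 h, tested at 50 uM (on this read-out lower numbers stand for less inhibition of growth and higher numbers for more inhibition of growth at the one concentration tested), compound 1 (`COc1ccc(/C=C/C(=O)/C=C/c2ccc(OCc3cn(CCCCCOc4cc(=O)oc5ccccc45)nn3)c(OC)c2)cc1OC`) gives 45% and compound 2 (`COc1cc(/C=C/C(=O)/C=C/c2cccc3ccccc23)ccc1OCc1cn(CCCCCOc2cc(=O)oc3ccccc23)nn1`) gives 42%. With only these two numbers available, compound 2 stands within the scatter of compound 1.

The next structure is compound 3 (`COc1cccc(/C=C/C(=O)/C=C/c2ccc(OCc3cn(CCCCCOc4cc(=O)oc5ccccc45)nn3)c(OC)c2)c1`), with 3-methoxyphenyl in place of naphthalen-1-yl on a double-bonded chain carbon bound to a double-bonded chain carbon.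

For the measured compounds named here, only one measured step bears on this change. At the same place, with naphthalen-1-yl in place of 3,4-dimethoxyphenyl, the series shows a number 3 percentage points lower from compound 1 to compound 2 (within the scatter). That step stays within the scatter, so exchanging these groups at this place has not yet moved the read-out measurably. Going by the values given here, no measured compound carries 3-methoxyphenyl itself, and a single step is a thin basis, so the range is kept wide.

The step expected in this assay is a number 2 percentage points higher from compound 2 to compound 3 (within the scatter), which means no change beyond the scatter and no firm direction. For compound 3 the estimated value is 44%, with an expected range of 32% to 56%.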

Compound 3, percent growth inhibition at one concentration: 36%
The estimate for compound 3 lay 8 percentage points above the measured number, and the stated range covers the measured number.
By their numbers in this assay, from the lowest: compounds 3, 2 and 1 (each within the scatter of the next).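

In this assay, for the compounds shown here, the exchange of naphthalen-1-yl for 3-methoxyphenyl on a double-bonded chain carbon bound to a double-bonded chain carbon gives a number 6 percentage points lower from compound 2 to compound 3 (within the scatter), so the read-out does not separate the two aromatic rings of carbon of the one group from the single methoxy-bearing ring of the other. The series also gains a step confined to one substituent, where hydrogen in place of methoxy on an aromatic carbon gives a number 9 percentage points lower from compound 1 to compound 3 (within the scatter), and this exchange likewise stays inside the usual variation of the assay. 3,4-dimethoxyphenyl, naphthalen-1-yl and 3-methoxyphenyl thus all remain unresolved at this place, and nothing measured on these compounds accounts for that flat picture.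

Going by these compounds, all three groups at this place carry no net charge and no hydrogen-bond donor, so it remains open whether an amine or a carboxylic acid on the aromatic ring would move the read-out beyond the scatter. The compounds shown also leave open whether a longer chain in place of the five-carbon link would change growth inhibition, since that part of the structure is common to all three.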